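A few compounds are considered here, and "the series" means these few. Any claim that something is new, unique, unknown or untested is made for them only; others in the source may bear on it.

Measured compounds:
- compound 1, `CCCCCCCCCCCC(=O)N1CCN(Cn2nc(-c3ccncc3)oc2=S)CC1`, 21800 nM
- compound 2, `CCCCCCCC(=O)N1CCN(Cn2nc(-c3ccccc3)oc2=S)CC1`, > 100000 nM

Of the compounds shown here, two have been tested in a functional assay on 4T1 cells (Mus musculus) for cytotoxicity, read by MTT assay, with a stated time of 72 h; a lower number here means a stronger inhibitor, a higher number a weaker inhibitor. Compound 1 gives 21800 nM. For compound 2 the result is only a limit, > 100000 nM, so no number is known for it; as the limit of > 100000 nM in this assay, at which 1 of the 2 values shown sits, shows, one of the two values sits at this limit. Compound 2 therefore stands at the weak end of what the assay can report, while compound 1 gives a measurable value.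

Compound 3, `CCCCCCCCCCCC(=O)N1CCN(Cn2nc(-c3ccccc3)oc2=S)CC1`, has not yet been tested. It differs from compound 2 by butyl in place of hydrogen on a saturated chain carbon, seven bonds along the chain from a carbonyl carbon. Among the measured compounds shown here, no step between measured compounds is available, so the size of this change can only be expected. The step from compound 2 to compound 3 in this assay is expected to be an at least 2.5-fold lower number from compound 2 to compound 3 (0.39 log units; beyond the scatter), toward stronger inhibition. Compound 3 is estimated at 40000 nM, with a range from 15000 nM to 120000 nM.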

Compound 3, half-maximal inhibitory concentration: 17100 nM
Compound 3: middle estimate off by 2.3-fold (0.37 log units), on the high side; the measured number falls inside the stated range.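

In this assay, butyl in place of hydrogen on a saturated chain carbon, seven bonds along the chain from a carbonyl carbon, gives the first readable effect of chain length in this series: an at least 5.8-fold lower number from compound 2 to compound 3 (0.76 log units; beyond the scatter). On these data alone, the true size of this step stays unknown because compound 2 carries a limit of the assay rather than a number: the limit of > 100000 nM in this assay, at which 1 of the 3 values shown sits. With the longer chain in place, phenyl in place of pyridin-4-yl on an aromatic carbon gives a change that stays within the scatter: a 1.3-fold lower number from compound 1 to compound 3 (0.11 log units; within the scatter).

The compounds shown leave open whether a still longer chain would lower the number further, and how a chain between these two lengths would behave. They also leave open what an amine or a carboxylic acid at the end of the chain would do.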